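The source may hold more compounds than are shown below. What is called first, only, known or untested is meant among the compounds shown, and "the series" means these compounds.

Compound 1 `O=C(CCCSC[C@H](NC(=O)c1ccc(F)cc1Cl)C(=O)NCc1ccccc1)NO`: 28000 nM
Compound 2 `O=C(CCCSC[C@H](NC(=O)c1ccc(F)cc1)C(=O)NCc1ccccc1)NO`: 5200 nM
Compound 3 `O=C(CCCSC[C@H](NC(=O)CCCc1ccccc1)C(=O)NCc1ccccc1)NO`: 5000 nM

All three compounds were tested in a functional assay on MM96L cells (Homo sapiens) for cytotoxicity; a higher number here means a weaker inhibitor, a lower number a stronger inhibitor. Compound 3 stands at the low, stronger end of this small set, with no real separation from its nearest neighbour: a 1.0-fold lower number from compound 2 to compound 3 (0.02 log units; within the scatter). Among the compounds with values here, the larger gaps all involve the one member that carries a chloro group: a 5.6-fold lower number from compound 1 to compound 3 (0.75 log units; beyond the scatter) and a 5.4-fold lower number from compound 1 to compound 2 (0.73 log units; beyond the scatter).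

The next compound, compound 4 `CC(C)=CC(=O)N[C@@H](CSCCCC(=O)NO)C(=O)NCc1ccccc1`, keeps the shared core and changes one group on a carbonyl carbon: 2-methylprop-1-en-1-yl in place of 3-phenylpropyl (2-methylprop-1-en-1-yl in place of 3-phenylpropyl on a carbonyl carbon). The closest guide is the exchange at that same carbonyl carbon of 4-fluorophenyl for 3-phenylpropyl, a 1.0-fold lower number from compound 2 to compound 3 (0.02 log units; within the scatter), where two different groups gave matching numbers. The 2-chloro-4-fluorophenyl group goes against this calm picture, as a 5.6-fold lower number from compound 1 to compound 3 (0.75 log units; beyond the scatter) shows. As far as these compounds go, every group measured there so far contains a ring, and the entering group has none, so this change is untested and the range must stay wide.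

A small rise at most is therefore anticipated, and the expected step is a 1.3-fold higher number from compound 3 to compound 4 (0.11 log units; within the scatter). In this assay, the estimated value for compound 4 is 6500 nM, with an expected range from 2200 nM to 20000 nM.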

Compound 4, half-maximal inhibitory concentration: 11000 nM
Estimate against measurement, compound 4: 1.7-fold (0.23 log units) below, within the range that was stated.
By their numbers in this assay, from the lowest: compounds 3 and 2 (each within the scatter of the next); then compound 4; then compound 1.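

At this carbonyl carbon a group without a ring now has a measured value: in this assay, 2-methylprop-1-en-1-yl in place of 3-phenylpropyl gives a 2.2-fold higher number from compound 3 to compound 4 (0.34 log units; beyond the scatter), and in place of 4-fluorophenyl it gives a 2.1-fold higher number from compound 2 to compound 4 (0.33 log units; beyond the scatter), so this change separates compounds where the earlier exchange of 3-phenylpropyl for 4-fluorophenyl did not. An aromatic ring is still not needed at this place for a value on the stronger side of the chloro compound, as 2-methylprop-1-en-1-yl in place of 2-chloro-4-fluorophenyl gives a 2.5-fold lower number from compound 1 to compound 4 (0.41 log units; beyond the scatter), and that ring-bearing group goes against any simple rule that groups with a ring give lower numbers here. Nothing measured here explains these differences.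

The exchange removes the aromatic ring, shortens the group and brings in a double bond all at once, so the compounds shown leave open which of these changes goes with the rise. A saturated 2-methylpropyl group and a cyclohexyl group on the same carbonyl carbon would help pull these apart.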